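Swapping methoxyamino for hydroxyamino in compound 3

The compounds below may be only part of what the source reports. "The series", "measured", "known", "first", "only" and "open" are said of these compounds alone.

In an ADME assay on MT4 cells (Homo sapiens) for cytotoxicity, read by spectrophotometry, with a stated time of 5 days (on this read-out lower numbers stand for higher toxicity in this test and higher numbers for lower toxicity in this test), compound 3 `CONC(=S)N/N=C1\C(=O)N(CN2CCN(c3ccc(OC)cc3)CC2)c2ccc(C)cc21` gives 324000 nM, within the scatter of both compound 1 `CONC(=S)N/N=C1\C(=O)N(CN2CCN(c3ccc(Cl)cc3)CC2)c2ccc(C)cc21` at 300000 nM and compound 2 `COc1ccc(N2CCN(CN3C(=O)/C(=N\NC(=S)NO)c4cc(F)ccc43)CC2)cc1` at 260000 nM. Compound 4 `COc1ccc(N2CCN(CN3C(=O)/C(=N\NC(=S)NO)c4cc(C)ccc43)CC2)cc1` comes from compound 3 by one change, hydrogen in place of methyl on an oxygen, turning methoxyamino into hydroxyamino: hydrogen in place of methyl on an oxygen. For the measured compounds named here, no measured step makes this exact change. Going by the values given here, the only measured step is a 1.1-fold higher number from compound 1 to compound 3 (0.03 log units; within the scatter), which puts methoxy in place of chloro on an aromatic carbon, a different place. Compound 2 already carries hydroxyamino, though its core differs, and stands at 260000 nM. The expected size in this assay is therefore a 1.2-fold lower number from compound 3 to compound 4 (0.06 log units; within the scatter), with no change beyond the scatter. The estimate for compound 4 is 280000 nM, with an expected range of 150000 nM to 450000 nM.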

Compound 4, half-maximal cytotoxic concentration: 321000 nM
For compound 4 the middle estimate is 1.1-fold (0.06 log units) below the measured one, and the stated range covers the measured number.
By their numbers in this assay, from the lowest: compounds 2, 1, 4 and 3 (each within the scatter of the next).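

In this assay, for the compounds shown here, hydrogen in place of methyl on an oxygen gives a 1.0-fold lower number from compound 3 to compound 4 (0.00 log units; within the scatter) on the same core, the first direct reading of methoxyamino to hydroxyamino, and the cytotoxicity number stays level. With hydroxyamino held fixed, methyl in place of fluoro on an aromatic carbon gives a 1.2-fold higher number from compound 2 to compound 4 (0.09 log units; within the scatter) and is likewise no real difference. Nothing available here offers an explanation for these level results. Still open, from the compounds shown here alone, is whether a longer chain on that oxygen, such as ethoxy, or a plain amine in place of hydroxyamino, would move the number beyond the scatter.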